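Coumarin Carboxamides as Weak Factor XII Inhibitors

The source may report more compounds than this note shows. Statements on the series, on what has been measured and on what is new or still open speak of the compounds shown alone.

Compound 1 `Cc1ccc2oc(=O)c(C(=O)NCc3ccccc3)cc2c1`: > 50000 nM
Compound 2 `Cc1ccc2oc(=O)c(C(=O)Nc3ccccc3C)cc2c1`: 32000 nM
Compound 3 `Cc1ccc2oc(=O)c(C(=O)Nc3ccccc3Cl)cc2c1`: 30000 nM

In an assay on isolated protein for inhibition of coagulation factor XII (Homo sapiens) (on this read-out lower numbers stand for stronger inhibition and higher numbers for weaker inhibition), compound 1 reaches only the limit of the limit of > 50000 nM in this assay, at which 1 of the 3 values shown sits, and that is not a number. Compound 2 gives 32000 nM in this assay. Compound 3 gives 30000 nM, the lowest of the two numbers, with compound 2 nearest at a gap within the scatter. The steps of an at least 1.5-fold lower number from compound 1 to compound 2 (0.19 log units; that floor lies within the scatter) and an at least 1.6-fold lower number from compound 1 to compound 3 (0.22 log units; that floor lies within the scatter) rest on a limit; the step of a 1.1-fold lower number from compound 2 to compound 3 (0.03 log units; within the scatter) is within the scatter.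

Compound 4 `Cc1ccc2oc(=O)c(C(=O)Nc3ccc(Cl)cc3)cc2c1` differs from compound 3 by 4-chlorophenyl in place of 2-chlorophenyl on an amide-type nitrogen. Among the measured compounds shown here, no measured step moves a chlorine from one place to another on that ring, so no step speaks to this change, and no step beyond the scatter is expected in this assay. Compound 4 is estimated at 30000 nM, between 8000 nM and 100000 nM, a step of no change at the digits printed from compound 3 to compound 4 (within the scatter).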

Compound 4, half-maximal inhibitory concentration: 34000 nM
Compound 4: the middle estimate sits 1.1-fold (0.05 log units) below what was measured, and the stated range covers the measured number.
By their numbers in this assay, from the lowest: compounds 3, 2 and 4 (each within the scatter of the next). At a limit, above all of these: compound 1.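

Setting 4-chlorophenyl in place of 2-chlorophenyl on the amide-type nitrogen gives a 1.1-fold higher number from compound 3 to compound 4 (0.05 log units; within the scatter), so where the chlorine sits on this ring makes no difference that can be read here. Putting 4-chlorophenyl in place of 2-methylphenyl gives a 1.1-fold higher number from compound 2 to compound 4 (0.03 log units; within the scatter), again no step beyond the scatter. The step of an at least 1.4-fold lower number from compound 1 to compound 4 (0.16 log units; that floor lies within the scatter) rests on the limit of compound 1, so it gives only a floor: the limit of > 50000 nM in this assay, at which 1 of the 4 values shown sits.

On these data alone, whether a carboxylic acid or an amine in place of the chlorine would shift the number beyond the scatter stays open.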